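Swapping Bromo for Nitro in Compound 3

This account rests on a few compounds, and the source may have more. Where it says the series, first, only, none or still open, it means among the compounds named here.

Measured in a functional assay on MCF7 cells (Homo sapiens) for inhibition, read by sulforhodamine B assay, with a stated time of 48 h; a lower number here means a stronger inhibitor of growth, a higher number a weaker inhibitor of growth:
- Compound 1 `CCOC(=O)c1nn(-c2ccccc2)c(-c2ccc(Cl)cc2)c1CNC(C)(C)C`: 72400 nM; > 559000 nM (2 entries)
- Compound 2 `CCOC(=O)c1nn(-c2ccccc2)c(-c2ccc(Br)cc2)c1CNC(C)(C)C`: 74200 nM; > 509000 nM (2 entries)
- Compound 3 `CC(C)(C)NCc1c(C(=O)O)nn(-c2ccccc2)c1-c1ccc(Br)cc1`: 293000 nM

The entries with a greater-than sign for compound 1 and compound 2 are limits of the assay, not numbers. Those two compounds have several entries each, whereas compound 3 has a single number, 293000 nM.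

Compound 4 `CC(C)(C)NCc1c(C(=O)O)nn(-c2ccccc2)c1-c1ccc([N+](=O)[O-])cc1` differs from compound 3 at one place, with nitro in place of bromo on an aromatic carbon, turning 4-bromophenyl into 4-nitrophenyl (nitro in place of bromo on an aromatic carbon). Among the compounds with values here, no measured pair of compounds shows what this swap does. Within the data shown here, the only anchor is compound 3 at 293000 nM. No change beyond the usual scatter, in either direction, is expected in this assay, giving an estimated step of a 1.0-fold lower number from compound 3 to compound 4 (0.02 log units; within the scatter). For compound 4 the estimated value is 280000 nM, with an expected range of 100000 nM to 700000 nM.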

Compound 4, concentration for 50% growth inhibition: > 634000 nM
Compound 4: no number, only a limit (the forecaster's own chance of this, stated with the estimate: 35%); middle value at least 2.2-fold (0.35 log units) away from the limit.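

In this assay, compound 4 gives only a limit, > 634000 nM, rather than a number. Even so, turning 4-bromophenyl into 4-nitrophenyl gives an at least 2.1-fold higher number from compound 3 to compound 4 (0.33 log units; beyond the scatter), the first measured step at this position. This position is therefore not indifferent to the change: nitro in place of bromo weakens growth inhibition beyond the usual scatter, by an amount not fixed from above. As far as these compounds go, how large the loss really is remains open, and so does whether another group in this place, such as an amine or a methoxy group, would keep the growth inhibition of compound 3.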